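Changing the Group on Sulfur in Compound 1

A few compounds are considered here, and "the series" means these few. Any claim that something is new, unique, unknown or untested is made for them only; others in the source may bear on it.

Measured compounds in a functional assay on DU-145 cells (Homo sapiens) for inhibition, read by trypan blue exclusion, with a stated time of 96 h; on this read-out lower numbers stand for stronger inhibition of growth and higher numbers for weaker inhibition of growth:
Compound 1 `Cc1ccc(CS/C(=C/c2ccc(C)s2)C(=O)c2ccc(Cl)cc2)cc1` gives 50000 nM.
Compound 2 `Cc1ccc(CS/C(=C/c2ccccc2F)C(=O)c2ccc(Cl)cc2)cc1` gives 10000 nM.
Compound 3 `Cc1ccc(CS/C(=C/c2cc([N+](=O)[O-])ccc2F)C(=O)c2ccc(Cl)cc2)cc1` gives 1000 nM.

Among the three measured compounds, compound 1 stands at the highest number in this assay. Its nearest neighbour is compound 2, reached by a 5.0-fold lower number from compound 1 to compound 2 (0.70 log units; beyond the scatter), and the furthest is compound 3, reached by a 50-fold lower number from compound 1 to compound 3 (1.70 log units; beyond the scatter). Between the two, a 10-fold lower number from compound 2 to compound 3 (1.00 log units; beyond the scatter) completes the picture. All three of these steps concern the aryl group on the double-bonded chain carbon, and none of them touches the sulfur substituent.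

Compound 4 `COc1ccc(S/C(=C/c2ccc(C)s2)C(=O)c2ccc(Cl)cc2)cc1` differs from compound 1 at that sulfur: 4-methoxyphenyl in place of 4-methylbenzyl on a sulfur. For the measured compounds named here, no measured step in this set bears on this position, so there is nothing in the data that points to a change in either direction. Compound 4 is therefore expected to give a number close to that of compound 1 in this assay, with no change at the digits printed from compound 1 to compound 4 (within the scatter) estimated as not beyond the scatter. The estimate for compound 4 is 50000 nM, with a range from 15000 nM to 150000 nM reflecting the absence of any guiding step.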

Compound 4, concentration for 50% growth inhibition: 50000 nM
Compound 4: the middle estimate sits on the measured number at the digits printed; measured number inside the range.
By their numbers in this assay, from the lowest: compound 3; then compound 2; then compounds 1 and 4 (each within the scatter of the next).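

For the compounds shown here, the sulfur substituent had not been touched by any earlier step, and this is the first reading of it: in this assay, 4-methoxyphenyl in place of 4-methylbenzyl on a sulfur gives no change at the digits printed from compound 1 to compound 4 (within the scatter). The two groups have 8 heavy atoms and one six-membered aromatic ring of carbon only each, but the entering group carries 1 hydrogen-bond acceptor where the leaving group carries 0, so this difference in composition comes with no change beyond the scatter when 5-methylthiophen-2-yl sits on the double-bonded chain carbon. No measurement shown here accounts for this result.

From the compounds shown here alone, the step is a single pair at the high end of the numbers, so it remains open whether the same exchange on sulfur would also leave the number unmoved with the 2-fluoro-5-nitrophenyl group of compound 3, which gives 1000 nM. Going by these compounds, it also remains open how the number would respond to a quite different group on this sulfur, such as a carboxylic acid on the aromatic ring, an amine or a longer chain.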